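Chloro for fluoro at one aromatic carbon

A few compounds are considered here, and "the series" means these few. Any claim that something is new, unique, unknown or untested is made for them only; others in the source may bear on it.

Among the measured compounds shown here, compound 2 `Fc1cccc(COc2nc3ccccc3s2)c1` gives 51.9% in a functional assay on the whole organism with Mus musculus as the target, in the writhing test, at a dose of 100 mg/kg by the intraperitoneal route (a lower number here means less inhibition, a higher number more inhibition at the dose given (going by the name of the read-out)), level with compound 1 `c1ccc(COc2nc3ccccc3s2)cc1` at 51.9%; the one measured step, no change at the digits printed from compound 1 to compound 2 (within the scatter), lies within the scatter. Compound 3 `Clc1ccccc1COc1nc2ccccc2s1` is reported only as "not active" (no number reported), a statement without a number. Compound 4 `Clc1cccc(COc2nc3ccccc3s2)c1` differs from compound 2 by chloro in place of fluoro on an aromatic carbon. For the measured compounds named here, no measured pair shows chloro in place of fluoro, so the only guides are no change at the digits printed from compound 1 to compound 2 (within the scatter) and the report for compound 3, which also carries chloro on that ring, "not active" (no number reported). A step of a number 13.9 percentage points lower from compound 2 to compound 4 (beyond the scatter) toward lower inhibition is therefore expected, with wide uncertainty. Compound 4 is estimated at 38%, within 10% to 60%.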

Compound 4, a percentage reported as inhibition, in the whole organism at one dose (the size of the read-out at that dose, not a potency): 51.9%
For compound 4 the middle estimate is 13.9 percentage points below the measured one; the range from low to high includes it.
By their numbers in this assay, from the lowest: compounds 1, 2 and 4 (each within the scatter of the next).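

In this assay, chloro on an aromatic carbon meta to a large group leaves the read-out unmoved, with no change at the digits printed from compound 2 to compound 4 (within the scatter) and no change at the digits printed from compound 1 to compound 4 (within the scatter). Hydrogen, fluoro and chloro at this position therefore cannot be told apart, so chloro on this ring does not by itself abolish the read-out, even though compound 3, with its chloro at another place on the ring, is reported as "not active" (no number reported). No available evidence accounts for this difference.

As far as these compounds go, it remains open whether a methoxy group, an amine or a carboxylic acid at this position would move the read-out beyond the scatter. The single dose also leaves open whether compounds 1, 2 and 4 would stay level at other doses.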